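Chloro for fluoro on the urea phenyl of compound 2

The compounds below may be only part of what the source reports. "The series", "measured", "known", "first", "only" and "open" are said of these compounds alone.

Measured so far:
compound 1 `CN(C)CCCNc1nc(-c2ccc(NC(=O)Nc3ccc(Cl)cc3)cc2)nc2c(Cl)c(Cl)sc12`: 230 nM
compound 2 `CCN(CC)CCCNc1nc(-c2ccc(NC(=O)Nc3ccc(F)cc3)cc2)nc2c(Cl)c(Cl)sc12`: 450 nM

In a functional assay on NCI-H460 cells (Homo sapiens) for cytotoxicity, read by MTT assay, with a stated time of 72 h (on this read-out higher numbers stand for weaker inhibition and lower numbers for stronger inhibition), compound 2 gives the higher of the two numbers, while compound 1 gives 230 nM, a gap that lies within the scatter; the two compounds also differ in more than one place, so their values say nothing about either change alone. Compound 3 `CCN(CC)CCCNc1nc(-c2ccc(NC(=O)Nc3ccc(Cl)cc3)cc2)nc2c(Cl)c(Cl)sc12` is compound 2 with chloro in place of fluoro on an aromatic carbon. Going by the values given here, with no single-change step between measured compounds available, the expected step in this assay is a 1.4-fold lower number from compound 2 to compound 3 (0.15 log units; within the scatter), a change not beyond the scatter. Compound 3 is therefore expected to give 320 nM, with a range from 140 nM to 750 nM.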

Compound 3, half-maximal inhibitory concentration: 270 nM
The estimate for compound 3 lay 1.2-fold (0.07 log units) above the measured number, and the stated range covers the measured number.
By their numbers in this assay, from the lowest: compounds 1, 3 and 2 (each within the scatter of the next).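

In this assay, going by these compounds alone, chloro in place of fluoro gives a 1.7-fold lower number from compound 2 to compound 3 (0.22 log units; within the scatter) and diethylamino in place of dimethylamino gives a 1.2-fold higher number from compound 1 to compound 3 (0.07 log units; within the scatter) as the first single changes that can be read on their own. Neither swap moves the number beyond the scatter, so for these three compounds, either halogen on the phenyl ring and either amine give values that cannot be told apart. No measurement at hand explains either result.

Still open, from the compounds shown here alone, is whether a methoxy or trifluoromethyl group on that phenyl ring, or a morpholine in place of the diethylamino group, would shift the number beyond the scatter.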